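The source may report more compounds than this note shows. Statements on the series, on what has been measured and on what is new or still open speak of the compounds shown alone.

Compound 1, `C=CC1=C(C(=O)Nc2ccc(OCC)cc2)C(c2ccc(OC)cc2)OC1` — in a functional assay on SW480 cells (Homo sapiens) for cytotoxicity, read by MTT assay, with a stated time of 24 h (on this read-out higher numbers stand for weaker inhibition and lower numbers for stronger inhibition), compound 1 gives > 100000 nM, a limit of the assay.
Compound 2, `C=CC1=C(C(=O)Nc2ccc(OCC)cc2)C(c2ccc(F)cc2)OC1` — in this assay compound 2 gives > 100000 nM, also a limit.
Compound 3, `C=CC1=C(C(=O)NCc2ccc(Cl)cc2)C(c2ccc(OC)c(OC)c2)OC1` — in this assay compound 3 gives > 100000 nM, again a limit.

Compound 1 thus stands at the limit of this assay rather than at a measured number, and every other value known here sits at that same limit, as the limit of > 100000 nM in this assay, at which 3 of the 3 values shown sit, records. Among the compounds with values here, the one step between two measured compounds, a step that the two limits leave unreadable from compound 1 to compound 2, cannot be read in size, since both ends are limits.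

Compound 4, `C=CC1=C(C(=O)NCc2ccc(C)cc2)C(c2ccc(OC)cc2)OC1`, has not yet been measured in this assay. It differs from compound 1 in one place: 4-methylbenzyl in place of 4-ethoxyphenyl on an amide-type nitrogen. Within the data shown here, no measured step touches this change directly. Compound 3 also carries a benzyl-type group on the amide nitrogen, and its value and that of compound 1 both sit at the limit, which is all that pair shows. Among the measured compounds shown here, there is therefore no measured step on which to base a sizeable movement in this assay in either direction for compound 4.

Compound 4 is accordingly expected to remain at or near the limit, estimated at 150000 nM, within a range from 60000 nM to 400000 nM. The step that this estimate implies, a step that the limit leaves unreadable from compound 1 to compound 4, is expected to be no more than the scatter.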

Compound 4, half-maximal inhibitory concentration: 31700 nM
Beside the measured number, compound 4's estimate is 4.7-fold (0.68 log units) above it, outside the stated range (below it).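

Replacing 4-ethoxyphenyl with 4-methylbenzyl on the amide-type nitrogen produces the first movement that can be read in this assay, with an at least 3.1-fold lower number from compound 1 to compound 4 (0.49 log units; beyond the scatter). This shows that the group on this nitrogen can shift the read-out, and since compound 1 sits at a limit, the step sets only a minimum size, so the true change may be larger. The earlier compounds could not show this, and the one step among them cannot be read, leaving compound 4 as the only compound here with a number rather than a limit: the limit of > 100000 nM in this assay, at which 3 of the 4 values shown sit.

The change alters both the link to the ring and the group on the ring, so the compounds shown do not say which of the two accounts for the step, and a 4-methylphenyl or a 4-ethoxybenzyl group on the same nitrogen would separate them. Compound 3 also has a benzyl-type group on that nitrogen but differs from compound 4 in more than one place, so it leaves open how far this step carries over to other benzyl groups, such as an unsubstituted benzyl or a 4-methoxybenzyl.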